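Cytotoxicity of a Sulfonamide Series: Amide to Arylsulfonyl Swap

A few compounds are considered here, and "the series" means these few. Any claim that something is new, unique, unknown or untested is made for them only; others in the source may bear on it.

Compound 3 `N#CC1=C(NC(=O)CCC(=O)O)N(c2ccc(S(N)(=O)=O)cc2)C2=C(C(=O)CCC2)C1c1ccc(Cl)cc1Cl` is measured in a functional assay on Ehrlich cells (Mus musculus) for cytotoxicity, read by trypan blue exclusion, with a stated time of 2 h (a lower number here means a stronger inhibitor, a higher number a weaker inhibitor), and gives 50 ug/mL; it has the lowest number among the compounds for which a number exists. Compound 2 `N#CC1=C(NC(N)=O)N(c2ccc(S(N)(=O)=O)cc2)C2=C(C(=O)CCC2)C1c1ccc(Cl)cc1Cl` gives 75 ug/mL, and the step of a 1.5-fold lower number from compound 2 to compound 3 (0.18 log units; within the scatter) lies within the scatter. For compound 1 `CCCCNC(=S)NC1=C(C#N)C(c2ccc(Cl)cc2Cl)C2=C(CCCC2=O)N1c1ccc(S(N)(=O)=O)cc1` only a limit is reported, > 100 ug/mL; the step of an at least 2.0-fold lower number from compound 1 to compound 3 (0.30 log units; that floor lies within the scatter) reaches only a floor that also lies within the scatter. Compound 4 `N#CC1=C(NS(=O)(=O)c2ccc(Br)cc2)N(c2ccc(S(N)(=O)=O)cc2)C2=C(C(=O)CCC2)C1c1ccc(Cl)cc1Cl` differs from compound 3 by (4-bromophenyl)sulfonyl in place of (2-carboxyethyl)carbonyl on an amine nitrogen. Within the data shown here, no measured step introduces an aromatic ring at this position, and the two steps onto compound 3 are both small, so no change beyond the scatter is expected: the estimated step is no change at the digits printed from compound 3 to compound 4 (within the scatter). Compound 4 is therefore expected to give about 50 ug/mL in this assay, within 20 ug/mL to 120 ug/mL.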

Compound 4, half-maximal inhibitory concentration: 5.5 ug/mL
Beside the measured number, compound 4's estimate is 9.1-fold (0.96 log units) above it, outside the stated range (below it).
By their numbers in this assay, from the lowest: compound 4; then compounds 3 and 2 (each within the scatter of the next). At a limit, above all of these: compound 1.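

In this assay, an aromatic ring on this amine nitrogen, carried by (4-bromophenyl)sulfonyl, brings steps beyond the scatter: a 9.1-fold lower number from compound 3 to compound 4 (0.96 log units; beyond the scatter) and a 14-fold lower number from compound 2 to compound 4 (1.13 log units; beyond the scatter). Among these compounds, the steps among the earlier compounds, whose groups here hold no ring, all lay within the scatter or reached only a floor within it. Compound 1 has only a limit, so an at least 18-fold lower number from compound 1 to compound 4 (1.25 log units; beyond the scatter) is a floor and not a measured size: the limit of > 100 ug/mL in this assay, at which 1 of the 4 values shown sits.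

Whether the sulfonyl link, the ring or the bromine accounts for the lower number stays open. A benzoyl group and an unsubstituted phenylsulfonyl group at this nitrogen would separate these parts.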